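This account rests on a few compounds, and the source may have more. Where it says the series, first, only, none or still open, it means among the compounds named here.

Compound 1 `N#Cc1c(-c2ccccc2)nc2c(c(-c3ccccc3)nn2-c2ccccc2)c1-c1ccc(O)cc1` carries a phenyl on the shared core, and in a functional assay on CCRF-CEM cells (Homo sapiens) for antiproliferative activity, read by resazurin assay, with a stated time of 72 h (on this read-out higher numbers stand for weaker inhibition and lower numbers for stronger inhibition), compound 1 gives 33400 nM. Compound 3 `COc1cc(-c2c(C#N)c(-c3ccco3)nc3c2c(-c2ccccc2)nn3-c2ccccc2)ccc1O` is a related analogue, and in this assay compound 3 gives 36500 nM. Compound 2 `N#Cc1c(-c2cccs2)nc2c(c(-c3ccccc3)nn2-c2ccccc2)c1-c1ccc(O)cc1` has thiophen-2-yl in place of the phenyl of compound 1. In this assay compound 2 reaches only a limit of the assay, > 25000 nM. The step that the limit leaves unreadable from compound 1 to compound 2 therefore cannot be sized, because of the limit of > 25000 nM in this assay, at which 1 of the 3 values shown sits. Compound 4 `N#Cc1c(-c2ccc(F)cc2)nc2c(c(-c3ccccc3)nn2-c2ccccc2)c1-c1ccc(O)cc1` differs from compound 2 by 4-fluorophenyl in place of thiophen-2-yl on an aromatic carbon. For the measured compounds named here, no measured step covers this exact change; the values of compound 1 and compound 3 point to weak inhibition throughout this small set. Compound 4 is thus expected to give 32000 nM, within a range of 15000 nM to 70000 nM. The expected step that the limit leaves unreadable from compound 2 to compound 4 is judged small, and a limit remains a real possibility.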

Compound 4, half-maximal inhibitory concentration: > 25000 nM
Compound 4 gave a limit, no number (the forecaster's own chance of this, stated with the estimate: 40%); the middle value is on the limit's open side.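

In this assay compound 4 reaches only a limit, > 25000 nM. For the compounds shown here, no step linking compound 4 to compound 1 or compound 2 can be read, because of this limit: the limit of > 25000 nM in this assay, at which 2 of the 4 values shown sit. Going by these compounds, whether phenyl, thiophen-2-yl and 4-fluorophenyl on the shared core differ at all in this assay stays open.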